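The compounds below may be only part of what the source reports. "The series", "measured", "known", "first", "only" and "open" are said of these compounds alone.

Working notes on the series. Compound 1 `CCC(COc1ccc(Cl)cc1)OC(=O)NCc1ccccc1` is tested in an assay for inhibition of zeta-carotene desaturase, chloroplastic/chromoplastic (Capsicum annuum), using a Dixon plot, with a stated time of 8 h; a higher number here means a weaker inhibitor, a lower number a stronger inhibitor. Compound 1 gives only a limit of the assay, > 100000 nM, not a number. Compound 2 `CCC(COc1cccc(C(C)C)c1)OC(=O)NCc1ccccc1` likewise gives a limit, > 100000 nM. Compound 3 `CCC(COc1cccc(C(=O)O)c1)OC(=O)NCc1ccccc1` also gives a limit, > 100000 nM. For the measured compounds named here, the single comparable step, a step that the two limits leave unreadable from compound 2 to compound 3, stays unreadable in size because every value sits at the limit of > 100000 nM in this assay, at which 3 of the 3 values shown sit. Compound 4 `CCC(COc1c(Cl)cccc1Cl)OC(=O)NCc1ccccc1` differs from compound 1 by 2,6-dichlorophenyl in place of 4-chlorophenyl on an oxygen on a saturated carbon. Going by the values given here, no measured step bears on this change, and compound 1 stands at the limit only. Compound 4 is expected near that limit too, estimated at 100000 nM with a range from 30000 nM to 300000 nM. The expected step of a number no higher from compound 1 to compound 4 (the limit leaves the size open) is thus none beyond the scatter, most likely reported again as a limit.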

Compound 4, half-maximal inhibitory concentration: > 100000 nM
Compound 4 was reported as a limit; the forecaster's own chance of this, stated with the estimate: 85%; the middle value lies on the limit itself.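

No new step can be read between compound 1 and compound 4, as both give only a limit. In this assay the compounds shown leave open which change to the shared core would give a number rather than a limit: the limit of > 100000 nM in this assay, at which 4 of the 4 values shown sit.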